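Lengthening the Imidazole Chain by One Carbon

The source may hold more compounds than are shown below. What is called first, only, known or untested is meant among the compounds shown, and "the series" means these compounds.

Measured so far:
- compound 1, `Cn1cc(C2=C(c3nn(CCCn4ccnc4)c4ncccc34)C(=O)N(c3ccccc3)C2=O)c2ccccc21`, in a functional assay on ECa-109 cells (Homo sapiens) for antiproliferative activity, read by MTT assay, with a stated time of 48 h (on this read-out lower numbers stand for stronger inhibition and higher numbers for weaker inhibition), gives 1440 nM
- compound 2, `CN1CCN(CCCn2nc(C3=C(c4cn(C)c5ccccc45)C(=O)NC3=O)c3cccnc32)CC1`, gives > 100000 nM in this assay, which is a limit of the assay and not a number

Going by the values given here, compound 1 supplies the only actual number in this assay; the other value shown is the limit of > 100000 nM in this assay, at which 1 of the 2 values shown sits. On the numbers shown, compound 1 therefore stands as the single point of reference for this assay.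

The unmeasured compound 3, `Cn1cc(C2=C(c3nn(CCCCn4ccnc4)c4ncccc34)C(=O)N(c3ccccc3)C2=O)c2ccccc21`, differs from compound 1 in one place: (1H-imidazol-1-yl)methyl in place of 1H-imidazol-1-yl on a saturated chain carbon, three bonds along the chain from an aromatic nitrogen. In plain terms, the 3-(1H-imidazol-1-yl)propyl chain becomes a 4-(1H-imidazol-1-yl)butyl chain, while the shared core and the rest of the molecule stay as they are.

Among the compounds with values here, no step between two measured compounds is available to show how such a chain extension behaves here. Compound 2 carries a different chain altogether and sits at a limit, so it gives no guidance on this change. The expected step of a 1.0-fold higher number from compound 1 to compound 3 (0.02 log units; within the scatter) is small, not beyond the usual scatter. Compound 3 is therefore estimated at 1500 nM, in a range from 500 nM to 5000 nM.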

Compound 3, half-maximal inhibitory concentration: 7540 nM
Estimate against measurement, compound 3: 5.0-fold (0.70 log units) below; measured number above the stated range.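

In this assay, going by these compounds alone, the change from the 3-(1H-imidazol-1-yl)propyl chain to the 4-(1H-imidazol-1-yl)butyl chain gives a 5.2-fold higher number from compound 1 to compound 3 (0.72 log units; beyond the scatter) and so provides the first step between two measured compounds that differ in one place. It shows that this chain is sensitive to its length, even though the imidazole ring stays and the shared core is untouched. The longer chain moves the read-out toward weaker inhibition by a modest amount that lies beyond the usual scatter, but nothing shown here explains this shift.

A single step cannot establish a trend, so a shorter 2-(1H-imidazol-1-yl)ethyl chain and a still longer 5-(1H-imidazol-1-yl)pentyl chain would be needed to show whether inhibition keeps weakening with length or is strongest at the propyl chain. From the compounds shown here alone, it also remains open whether the imidazole ring itself matters at the end of the chain, a question that a simple dimethylamine or a carboxylic acid in its place on the same core could help to answer.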